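A few compounds are considered here, and "the series" means these few. Any claim that something is new, unique, unknown or untested is made for them only; others in the source may bear on it.

Measured compounds:
- Compound 1, `CC(C)(C)c1ccc(NC(=O)c2ccc(-c3ccccn3)cc2)cc1`, gives 11 nM in a functional assay for antagonist activity at transient receptor potential cation channel subfamily V member 1 (Homo sapiens), read by FLIPR; on this read-out higher numbers stand for weaker inhibition and lower numbers for stronger inhibition.
- Compound 2, `CCCOc1cccnc1-c1ccc(C(=O)Nc2ccc(C(C)(C)C)cc2)cc1`, gives 62 nM in this assay.
- Compound 3, `CC(C)(C)c1ccc(NC(=O)c2ccc(-c3ncccc3N(S(C)(=O)=O)S(C)(=O)=O)cc2)cc1`, gives 0.8 nM in this assay.

Compound 3 has the lowest number of the three, and its steps to both others lie beyond the scatter. The substituent on the shared core matters a great deal here: propoxy in place of hydrogen gave a 5.6-fold higher number from compound 1 to compound 2 (0.75 log units; beyond the scatter), while bis(methylsulfonyl)amino in place of hydrogen gave a 14-fold lower number from compound 1 to compound 3 (1.14 log units; beyond the scatter) and in place of propoxy gave a 78-fold lower number from compound 2 to compound 3 (1.89 log units; beyond the scatter).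

Compound 4, `CC(C)(C)c1ccc(NC(=O)c2ccc(-c3ncccc3C(=O)O)cc2)cc1`, carries carboxy in place of bis(methylsulfonyl)amino on an aromatic carbon. Among the compounds with values here, no measured step involves carboxy, so the expectation rests on the spread already seen: the bare hydrogen of compound 1 and the propoxy of compound 2 both sit well above compound 3. Removing the bis(methylsulfonyl)amino group is therefore expected to give a higher number, and compound 4 is estimated at 30 nM, within 5 nM to 200 nM, a step of a 38-fold higher number from compound 3 to compound 4 (1.57 log units; beyond the scatter).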

Compound 4, half-maximal inhibitory concentration: > 4000 nM
Compound 4: only a limit was reported (the forecaster's own chance of this, stated with the estimate: 10%); middle value at least 130-fold (2.12 log units) from the limit.
By their numbers in this assay, from the lowest: compound 3; then compound 1; then compound 2. At a limit, above all of these: compound 4.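

Compound 4 gives only a limit, not a number: the limit of > 4000 nM in this assay, at which 1 of the 4 values shown sits.

The carboxy swap gives an at least 5000-fold higher number from compound 3 to compound 4 (3.69 log units; beyond the scatter), and the same group also compares poorly with the other two, with an at least 360-fold higher number from compound 1 to compound 4 (2.56 log units; beyond the scatter) and an at least 64-fold higher number from compound 2 to compound 4 (1.80 log units; beyond the scatter). The earlier compounds shown here showed that a group at this position can strengthen or weaken inhibition, but compound 4 adds that a substituent here can do far worse than the bare hydrogen of compound 1, and further than propoxy did.

Carboxy differs from bis(methylsulfonyl)amino in several ways at once, including its hydrogen-bond donor, so these compounds cannot say which difference matters. Going by these compounds, a methyl ester or a primary amide at this position would help to separate them, and how weak compound 4 really is remains unknown.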